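This account rests on a few compounds, and the source may have more. Where it says the series, first, only, none or still open, it means among the compounds named here.

Measured in an ADME assay on liver for metabolic stability, with Liver microsome (Homo sapiens) as the target, read by LC-MS, using microsomes; a lower number here means slower removal, a higher number faster removal of the compound:
- Compound 1 `CC(C)(C)OC[C@@H](O)C(=O)N1[C@H](C(=O)NCc2cc(Cl)ccc2-n2cnnn2)C[C@@H]2C[C@@H]21`: 21 mL.min-1.g-1
- Compound 2 `CC(C)(C)[C@@H](O)C(=O)N1C[C@H]2C[C@H]2[C@H]1C(=O)NCc1cc(Cl)ccc1-n1cnnn1`: 22 mL.min-1.g-1
- Compound 3 `O=C(NCc1cc(Cl)ccc1-n1cnnn1)[C@@H]1C[C@H]2C[C@H]2N1C(=O)[C@H](O)c1cccc(F)c1`: 32 mL.min-1.g-1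

Compound 1 stands within the usual scatter of both compound 2 and compound 3, so the three cannot be told apart in this measurement. Compound 4 `O=C(NCc1cc(Cl)ccc1-n1cnnn1)[C@@H]1C[C@@H]2C[C@@H]2N1C(=O)[C@H](O)c1ccccc1F` has 2-fluorophenyl in place of (tert-butoxy)methyl on a saturated chain carbon bound to a carbonyl carbon and an oxygen on a saturated carbon. Going by the values given here, no measured pair shows this change directly. The closest guide is compound 3, which also carries a fluorophenyl group and gives 32 mL.min-1.g-1. The expected step of a 1.3-fold higher number from compound 1 to compound 4 (0.12 log units; within the scatter) is small, towards faster removal, and probably within the scatter. Compound 4 is expected at 28 mL.min-1.g-1, with an estimated range of 15 mL.min-1.g-1 to 50 mL.min-1.g-1.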

Compound 4, intrinsic clearance in microsomes: < 12 mL.min-1.g-1
Compound 4: a limit, no number; the forecaster's own chance of this, stated with the estimate: 2%; middle value at least 2.3-fold (0.36 log units) away from the limit.
By their numbers in this assay, from the lowest: compounds 1, 2 and 3 (each within the scatter of the next). At a limit, below all of these: compound 4.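

In this assay, 2-fluorophenyl in place of (tert-butoxy)methyl gives an at least 1.7-fold lower number from compound 1 to compound 4 (0.24 log units; that floor lies within the scatter). The result for compound 4 is a limit of the assay, not a number: the limit of < 12 mL.min-1.g-1 in this assay, at which 1 of the 4 values shown sits. The earlier compounds shown here did not show that this change, on a saturated chain carbon bound to a carbonyl carbon and an oxygen on a saturated carbon, can bring in an aromatic ring without faster removal.

From the compounds shown here alone, how far the step really reaches stays open. So does what a plain phenyl or an amine would give in this place.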